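Swapping the methoxy-bearing ring for a difluorinated one

This account rests on a few compounds, and the source may have more. Where it says the series, first, only, none or still open, it means among the compounds named here.

Three related compounds have been measured in a functional assay on SNB-19 cells (Homo sapiens) for cytotoxicity, read by sulforhodamine B assay, with a stated time of 48 h, tested at 10 uM; on this read-out lower numbers stand for a stronger effect and higher numbers for a weaker effect at the one concentration tested. Compound 1 `COc1ccc(-c2cc(/C=C/C(=O)c3ccc(OC)c(OC)c3)[nH]n2)cc1` gives -31%, compound 2 `COc1ccc(-c2cc(/C=C/C(=O)c3ccc(N)cc3)[nH]n2)cc1OC` gives 31%, and compound 3 `COc1ccc(C(=O)/C=C/c2cc(-c3cc(OC)c(OC)c(OC)c3)n[nH]2)cc1` gives -85%, the lowest number of the three and thus the strongest effect in this assay, beyond the scatter in both comparisons.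

Compound 4 `COc1cc(-c2cc(/C=C/C(=O)c3ccc(F)c(F)c3)[nH]n2)cc(OC)c1OC` differs from compound 3 in one place: 3,4-difluorophenyl in place of 4-methoxyphenyl on a carbonyl carbon. Among the compounds with values here, no measured pair shows this exact change, so its effect is uncertain. The expectation is a move toward a higher number, that is a somewhat weaker effect, with the step from compound 3 to compound 4 estimated at a number 35 percentage points higher from compound 3 to compound 4 (beyond the scatter). Compound 4 is therefore expected to give about -50% in this assay, within a range from -95% to 20%.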

Compound 4, a percentage reported as activity, at one concentration (the size of the read-out at that concentration, not a potency): 25%
Estimate against measurement, compound 4: 75 percentage points below; measured number above the stated range.
By their numbers in this assay, from the lowest: compound 3; then compound 1; then compounds 4 and 2 (each within the scatter of the next).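

In this assay, 3,4-difluorophenyl in place of 4-methoxyphenyl on a carbonyl carbon gives a number 110 percentage points higher from compound 3 to compound 4 (beyond the scatter). Within the data shown here, this is the first comparison here of compounds that differ in one place, and it shows that the group at this position matters greatly: with the rest of the molecule unchanged, the strong effect of compound 3 is not kept. No evidence is available that explains this step. As far as these compounds go, whether the methoxy group's loss or the fluorines' arrival drives the change remains open. A plain phenyl or 4-fluorophenyl group at this position could help separate the two.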